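The compounds below may be only part of what the source reports. "The series", "measured", "known", "first", "only" and "open" are said of these compounds alone.

In a functional assay on the whole organism with Rattus norvegicus as the target (a higher number here means that more compound is needed for the effect, a lower number that less compound is needed), compound 1 (`CCOCCOC(=O)C(=O)Nc1nc(-c2cc(Cl)no2)cs1`) gives 6 mg/kg. For compound 2 (`CCOCCOC(=O)C(=O)Nc1nc(-c2c(-c3c(F)cccc3Cl)noc2C)cs1`) the result is only a limit, > 10 mg/kg. Compound 3 (`O=C(O)C(=O)Nc1nc(-c2cc(Cl)no2)cs1`) also stands at a limit, > 30 mg/kg. Moving on to compound 4 (`Cc1cc(-c2csc(NC(=O)C(=O)O)n2)on1`) brings (methyl in place of chloro on an aromatic carbon), with methyl in place of chloro on an aromatic carbon. Within the data shown here, the one measured step, an at least 5.0-fold higher number from compound 1 to compound 3 (0.69 log units; beyond the scatter), put hydrogen in place of 2-ethoxyethyl at a different place and left the chloro untouched. It therefore gives no direct size for this swap, and no change beyond the scatter is expected in this assay. The expected step is a number no higher from compound 3 to compound 4 (the limit leaves the size open). Compound 4 is estimated at 30 mg/kg, with an expected range from 12 mg/kg to 80 mg/kg.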

Compound 4, dose for half-maximal effect: 0.3 mg/kg
For compound 4 the middle estimate is 100-fold (2.00 log units) above the measured one; measured number outside the range, below it.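

At this position, next to the ring nitrogen, exchanging chloro for methyl swaps just one heavy atom for another, yet it gives an at least 100-fold lower number from compound 3 to compound 4 (2.00 log units; beyond the scatter) in this assay. Among these compounds, the only earlier step changed the 2-ethoxyethyl group, so this is the first sign that a small change on this ring carbon can matter greatly. Compound 3 stands at a limit, so the full size of the step stays unknown: the limit of > 30 mg/kg in this assay, at which 1 of the 4 values shown sits.

From the compounds shown here alone, whether ethyl or an amine here would match methyl remains open. So does whether methyl gives a similar gain when the 2-ethoxyethyl group of compound 1 is kept.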